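Thiophen-2-yl for 4-Nitrophenyl at the Aromatic Carbon

The source may report more compounds than this note shows. Statements on the series, on what has been measured and on what is new or still open speak of the compounds shown alone.

Compound 3 `O=C(Cn1cc(-c2ccc([N+](=O)[O-])cc2)nn1)Nc1nc2ccccc2s1` gives 3280 nM in a functional assay on BMDM cells (Mus musculus, strain C57BL/6) for inhibition, with a stated time of 2 days (a higher number here means a weaker inhibitor, a lower number a stronger inhibitor), the second highest of the three numbers; compound 2 `COc1ccc(-c2cn(CC(=O)Nc3nc(C)cs3)nn2)cc1` gives 3890 nM, which lies within the scatter of compound 3, while compound 1 `O=C(Cn1cc(-c2ccc([N+](=O)[O-])cc2)nn1)Nc1nccs1` gives 1040 nM, a step of a 3.2-fold higher number from compound 1 to compound 3 (0.50 log units; beyond the scatter). Compound 4 `O=C(Cn1cc(-c2cccs2)nn1)Nc1nc2ccccc2s1` differs from compound 3 at another place: thiophen-2-yl in place of 4-nitrophenyl on an aromatic carbon. Going by the values given here, no measured step concerns that aromatic carbon, and compound 1 and compound 2 differ there and elsewhere at once, so their numbers give no clean guide. Among the compounds with values here, with no bearing step, no change beyond the scatter is expected, so compound 4 is estimated at 3500 nM, between 1400 nM and 9000 nM, a step of a 1.1-fold higher number from compound 3 to compound 4 (0.03 log units; within the scatter).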

Compound 4, half-maximal inhibitory concentration: 21400 nM
The estimate for compound 4 lay 6.1-fold (0.79 log units) below the measured number, and the stated range ends below it.
By their numbers in this assay, from the lowest: compound 1; then compounds 3 and 2 (each within the scatter of the next); then compound 4.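

The aromatic carbon of the five-membered ring with 3 nitrogen does respond to its substituent: in this assay thiophen-2-yl in place of 4-nitrophenyl gives a 6.5-fold higher number from compound 3 to compound 4 (0.81 log units; beyond the scatter) and so weakens inhibition. This single step was read with 1,3-benzothiazol-2-yl on the amide-type nitrogen. No measurement at hand gives a reason for the step.

Going by these compounds, whether the same change has a similar effect with 1,3-thiazol-2-yl on that nitrogen remains open. So does whether the difference follows the nitro group or the ring itself, which a plain phenyl or a 4-aminophenyl group at this carbon could help separate.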